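A 4-cyanophenyl Swap in a Level Series

A few compounds are considered here, and "the series" means these few. Any claim that something is new, unique, unknown or untested is made for them only; others in the source may bear on it.

In a functional assay on THP-1 cells (Homo sapiens) for cytotoxicity, read by MTT assay, with a stated time of 24 h (a lower number here means a stronger inhibitor, a higher number a weaker inhibitor), compound 1 `COc1cc(/C=C2\CN(C)C/C(=C\c3ccccc3F)C2=O)cc(OC)c1OC` gives 640 nM, compound 2 `COc1cc(/C=C2\CN(C)C/C(=C\c3cc(OC)c(OC)c(OC)c3)C2=O)cc(OC)c1` gives 720 nM and compound 3 `COc1cc(/C=C2\CN(C)C/C(=C\c3cccc([N+](=O)[O-])c3)C2=O)cc(OC)c1OC` gives 890 nM. The three stand level, with compound 3 inside the scatter of both others. The measured steps are a 1.4-fold higher number from compound 1 to compound 3 (0.14 log units; within the scatter) and a 1.2-fold higher number from compound 2 to compound 3 (0.09 log units; within the scatter), and the remaining one is a 1.1-fold higher number from compound 1 to compound 2 (0.05 log units; within the scatter).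

Compound 4 `COc1cc(/C=C2\CN(C)C/C(=C\c3ccc(C#N)cc3)C2=O)cc(OC)c1OC` is changed at the same place as these steps: 4-cyanophenyl in place of 3-nitrophenyl on a double-bonded chain carbon bound to a double-bonded ring carbon. The change sits on a double-bonded chain carbon bound to a double-bonded ring carbon. Within the data shown here, no measured compound carries the 4-cyanophenyl group, so the three steps bear on it only indirectly. They do show that exchanging 2-fluorophenyl, 3,5-dimethoxyphenyl and 3-nitrophenyl at this place has so far stayed within the scatter. No step beyond the scatter is therefore expected, in either direction. The expected size is a 1.2-fold lower number from compound 3 to compound 4 (0.07 log units; within the scatter). In this assay, the estimate for compound 4 is 750 nM, expected to fall between 350 nM and 1600 nM.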

Compound 4, half-maximal inhibitory concentration: 820 nM
Compound 4: the middle estimate sits 1.1-fold (0.04 log units) below what was measured; the range from low to high includes it.
By their numbers in this assay, from the lowest: compounds 1, 2, 4 and 3 (each within the scatter of the next).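

In this assay, the 4-cyanophenyl group stands level with all three groups tested before it at this place, with each step within the scatter (a 1.1-fold lower number from compound 3 to compound 4 (0.04 log units; within the scatter); a 1.1-fold higher number from compound 2 to compound 4 (0.06 log units; within the scatter); a 1.3-fold higher number from compound 1 to compound 4 (0.11 log units; within the scatter)). The level series on a double-bonded chain carbon bound to a double-bonded ring carbon thus now extends to a group with a triple bond outside aromatic rings, and exchanging 3-nitrophenyl, with 9 heavy atoms and 2 hydrogen-bond acceptors, for 4-cyanophenyl, with 8 heavy atoms and 1 hydrogen-bond acceptor, leaves the number within the scatter. No supporting data are available to explain this flat result.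

On these data alone, whether a phenyl ring carrying an amine or a carboxylic acid at this place would step beyond the scatter remains open. The same is true of a longer chain between the ring and the double-bonded chain carbon.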